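A Protected Amine Added to Two Chain Lengths

The compounds below may be only part of what the source reports. "The series", "measured", "known", "first", "only" and "open" are said of these compounds alone.

Compound 1 `CC(=O)N1CCC[C@H]1COCCCCCC/C=C/c1ccc(-c2ccccc2)cc1` and compound 2 `CC(=O)N1CCC[C@H]1COCCCCCCCCC/C=C/c1ccc(-c2ccccc2)cc1` share a core that appears in two versions differing in the length of the ether-linked chain; the difference between the two cores is not broken down here. In a functional assay on PANC-1 cells (Homo sapiens) for inhibition, read by XTT assay, with a stated time of 72 h (a lower number here means a stronger inhibitor, a higher number a weaker inhibitor), compound 1 gives 65000 nM, and compound 2 gives 70000 nM. The two values lie within the scatter of each other, so nothing separates them.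

Compound 3 `CC(C)(C)OC(=O)NCC(=O)N1CCC[C@H]1COCCCCCC/C=C/c1ccc(-c2ccccc2)cc1` carries the change (tert-butoxycarbonyl)amino in place of hydrogen on a saturated chain carbon bound to a carbonyl carbon on the core of compound 1. In this assay compound 3 gives 66700 nM. The step of a 1.0-fold higher number from compound 1 to compound 3 (0.01 log units; within the scatter) is within the scatter, so adding the (tert-butoxycarbonyl)amino group to the shorter-chain core left the number essentially where it stood.

Compound 4 `CC(C)(C)OC(=O)NCC(=O)N1CCC[C@H]1COCCCCCCCCC/C=C/c1ccc(-c2ccccc2)cc1` applies the same change, ((tert-butoxycarbonyl)amino in place of hydrogen on a saturated chain carbon bound to a carbonyl carbon), to the core of compound 2; the place of the change is worded identically in both cases, on a saturated chain carbon bound to a carbonyl carbon. The change from compound 1 to compound 3 and the change from compound 2 to compound 4 are the only two occurrences of this substitution among the compounds shown. The account expects the step of no change at the digits printed from compound 2 to compound 4 (within the scatter) to be flat because the analogous step a 1.0-fold higher number from compound 1 to compound 3 (0.01 log units; within the scatter) was within the scatter, and because compound 2 with 70000 nM sits at the same level as compound 1. Compound 4 is therefore estimated at 70000 nM in this assay, with a likely range from 40000 nM to 120000 nM.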

Compound 4, half-maximal inhibitory concentration: > 100000 nM
Compound 4 ended at the assay's limit; the forecaster's own chance of this, stated with the estimate: 20%; middle value at least 1.4-fold (0.15 log units) away from the limit.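

In this assay compound 4 gives > 100000 nM, which is a limit of the assay and not a number. On the longer-chain core, the (tert-butoxycarbonyl)amino change therefore gives an at least 1.4-fold higher number from compound 2 to compound 4 (0.15 log units; that floor lies within the scatter), a step that has a floor but no upper end, so its true size cannot be read. The result shows neither that the change carries over to the second core with the same flat outcome nor that it behaves differently there: the same change on two cores in this assay, a 1.0-fold higher number (0.01 log units; within the scatter) from compound 1 to compound 3 and an at least 1.4-fold higher number (0.15 log units; that floor lies within the scatter) from compound 2 to compound 4; the limit leaves it open whether they differ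

The compounds shown leave open how far beyond the limit compound 4 really lies, and a measured number for it would be needed before the two steps could be properly compared: the limit of > 100000 nM in this assay, at which 1 of the 4 values shown sits. They also leave open whether an amine in place of the (tert-butoxycarbonyl)amino group, or a chain longer than either of the two ether-linked chains here, would give a value that stands clearly apart from these in this assay.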